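Bromo in place of chloro in a small series

This account rests on a few compounds, and the source may have more. Where it says the series, first, only, none or still open, it means among the compounds named here.

Values so far in a functional assay on L1210 cells (Mus musculus) for antiproliferative activity, read by cell counting, with a stated time of 48 h (on this read-out higher numbers stand for weaker inhibition and lower numbers for stronger inhibition), are these.
- compound 1 `C#C[C@@]1(O)[C@@H](CO)O[C@@H](n2cc(I)c3c(N)ncnc32)[C@@H]1O` gives 56 nM
- compound 2 `C#C[C@@]1(O)[C@@H](CO)O[C@@H](n2cc(Cl)c3c(Cl)ccnc32)[C@@H]1O` gives 75000 nM

Of the two, compound 2 has the higher number (75000 nM), which means the weaker inhibition, and its gap to compound 1 (56 nM) lies beyond the scatter. The two differ in more than one place, so that gap cannot be tied to any single group.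

The unmeasured compound 3 `C#C[C@@]1(O)[C@@H](CO)O[C@@H](n2cc(Br)c3c(Cl)ccnc32)[C@@H]1O` is compound 2 with bromo in place of chloro on an aromatic carbon, two ring bonds from the ring nitrogen (bromo in place of chloro on an aromatic carbon). Within the data shown here, no measured pair shows this exchange, so the series gives no direct size for it. The starting point is compound 2 at 75000 nM, and in this assay no step beyond the scatter is expected, in either direction. The expected step is small (a 1.5-fold lower number from compound 2 to compound 3 (0.18 log units; within the scatter)) on this estimate. Compound 3 is estimated at 50000 nM with an expected range from 15000 nM to 150000 nM in this read-out.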

Compound 3, half-maximal inhibitory concentration: 30000 nM
The estimate for compound 3 lay 1.7-fold (0.22 log units) above the measured number, within the range that was stated.
By their numbers in this assay, from the lowest: compound 1; then compound 3; then compound 2.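

In this assay, bromo in place of chloro on the aromatic carbon two ring bonds from the ring nitrogen gives the series its first comparison that differs in one place (a 2.5-fold lower number from compound 2 to compound 3 (0.40 log units; beyond the scatter)). This position is therefore not indifferent to the identity of its halogen, although the step is modest and compound 3 remains at a high number on this read-out. The two groups match in heavy-atom count and in hydrogen-bond donors and acceptors, and nothing measured here accounts for the step.

As far as these compounds go, whether a methyl group, a nitrile or an amine on this same aromatic carbon would move the number further, and in which direction, remains open, as does whether the exchange would give a step of similar size on the core of compound 1. The large gap between compound 1 and the two halogenated compounds still cannot be tied to any single group, since compound 1 differs from each of them in more than one place.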